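The source may hold more compounds than are shown below. What is called first, only, known or untested is meant among the compounds shown, and "the series" means these compounds.

Measured compounds in a functional assay on Jurkat cells (Homo sapiens) for activation, with a stated time of 24 h; on this read-out higher numbers stand for an effect only at larger amounts of compound and lower numbers for an effect already at smaller amounts:
Compound 1 `Oc1ccccc1CNc1ccc(F)cc1`: "not active" (no number reported)
Compound 2 `O=[N+]([O-])c1ccc(NCc2ccccc2O)cc1`: "not active" (no number reported)
Compound 3 `Oc1ccccc1CNc1ccc(-c2ccccc2)cc1`: 1820 nM

Of the compounds shown here, three sharing one core have been tested. For compound 1 and compound 2 the result was only a word, not a number: each came back as not active, so no concentration can be placed beside them. Within the data shown here, compound 3 is therefore the only compound with a number in this assay, and it stands alone as the sole reference point for anything that follows.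

Compound 4 `COC(=O)c1ccc(-c2ccc(NCc3ccccc3O)cc2)cc1` has not yet been measured. Compared with compound 3 it carries one change: methoxycarbonyl in place of hydrogen on an aromatic carbon. Nothing else in the molecule moves.

Among the measured compounds shown here, with no pair of measured compounds differing in a single place, there is no measured step to lean on. For the measured compounds named here, the only guidance is that compound 3, the one compound here with a larger group on that part of the core, gave 1820 nM, while the two compounds with smaller groups gave no number at all. On that basis the step from compound 3 to compound 4 is expected to be small, in no clear direction and likely within the usual scatter, as a 1.2-fold lower number from compound 3 to compound 4 (0.08 log units; within the scatter). Compound 4 is expected to give about 1500 nM, with a range from 500 nM to 4500 nM.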

Compound 4, half-maximal effective concentration: "not active" (no number reported)
Nothing numeric was reported for compound 4; no gap can be computed for the estimate.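

In this assay, among these compounds, compound 4 gave no number, so no step from compound 3 to compound 4 can be read. No available evidence explains this result. The compounds shown leave open whether any group other than methoxycarbonyl at that place would give a number, and how that number would compare with compound 3.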